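Amide Nitrogen Substituent Changes in a Glutathione Transferase Series

The compounds below may be only part of what the source reports. "The series", "measured", "known", "first", "only" and "open" are said of these compounds alone.

Compound 1, `COc1ccccc1NC(=O)CCC(=O)OCCCCCCSc1ccc([N+](=O)[O-])c2nonc12`, 280 nM
Compound 2, `O=C(CCC(=O)OCCCCCCSc1ccc([N+](=O)[O-])c2nonc12)Nc1ccc(Br)cc1`, 32000 nM
Compound 3, `O=C(CCC(=O)OCCCCCCSc1ccc([N+](=O)[O-])c2nonc12)Nc1ccc(C(F)(F)F)cc1`, 90 nM

In an assay on isolated protein for inhibition of glutathione S-transferase Mu 2 (Homo sapiens), with a stated time of 10 min (on this read-out lower numbers stand for stronger inhibition and higher numbers for weaker inhibition), compound 3 gives the lowest number of the three; compound 1 lies a 3.1-fold lower number from compound 1 to compound 3 (0.49 log units; beyond the scatter) apart, and compound 2 lies a 360-fold lower number from compound 2 to compound 3 (2.55 log units; beyond the scatter) apart. Every measured compound carries the same core, and the only point of variation is the group on the amide-type nitrogen.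

Compound 4, `O=C(CCC(=O)OCCCCCCSc1ccc([N+](=O)[O-])c2nonc12)NCCN1CCCC1`, continues this pattern: 2-(pyrrolidin-1-yl)ethyl in place of 4-(trifluoromethyl)phenyl on an amide-type nitrogen. For the measured compounds named here, no measured step swaps an aryl group for an open-chain amine at this position, so the measured steps bear on it only indirectly. They show that the group on this nitrogen can shift the number a great deal, as in a 360-fold lower number from compound 2 to compound 3 (2.55 log units; beyond the scatter), or modestly, as in a 3.1-fold lower number from compound 1 to compound 3 (0.49 log units; beyond the scatter). Because compound 3 stands at 90 nM with the aromatic ring present in all three measured compounds, and because even a 110-fold higher number from compound 1 to compound 2 (2.06 log units; beyond the scatter) arose from a change within aryl groups, the loss of that ring is expected to move the number upward, towards weaker inhibition, by a step of a 33-fold higher number from compound 3 to compound 4 (1.52 log units; beyond the scatter). Compound 4 is therefore estimated at 3000 nM, with a range from 300 nM to 30000 nM.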

Compound 4, half-maximal inhibitory concentration: 200 nM
Estimate against measurement, compound 4: 15-fold (1.18 log units) above; the whole stated range lies above it.
By their numbers in this assay, from the lowest: compound 3; then compounds 4 and 1 (each within the scatter of the next); then compound 2.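

Compound 4 shows that an aromatic ring on the amide-type nitrogen is not needed for a low number in this assay: replacing 4-(trifluoromethyl)phenyl with 2-(pyrrolidin-1-yl)ethyl gives only a 2.2-fold higher number from compound 3 to compound 4 (0.35 log units; beyond the scatter) as a modest step. The same open-chain group cannot be told apart from the 2-methoxyphenyl of compound 1 (a 1.4-fold lower number from compound 1 to compound 4 (0.15 log units; within the scatter)), yet it stands far from the 4-bromophenyl of compound 2 (a 160-fold lower number from compound 2 to compound 4 (2.20 log units; beyond the scatter)), so among these four compounds, compound 2 is the one set well apart, and an aryl group at this place does not by itself give the lower numbers. Nothing available here accounts for these steps.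

As far as these compounds go, whether this tolerance extends to other groups on this nitrogen remains open, for instance a 2-(morpholin-4-yl)ethyl group, a 3-(pyrrolidin-1-yl)propyl chain or a chain ending in a carboxylic acid. The large gap between the 4-bromophenyl and 4-(trifluoromethyl)phenyl compounds also leaves open where a 4-chlorophenyl or 4-methylphenyl group would fall.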